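The compounds below may be only part of what the source reports. "The series", "measured", "known", "first", "only" and "open" are said of these compounds alone.

In a functional assay on RAW264.7 cells (Mus musculus) for inhibition, read by Griess assay, with a stated time of 18 h (a higher number here means a weaker inhibitor, a lower number a stronger inhibitor), compound 1 `COc1c(/C=C/C(=O)c2ccc(O)cc2O)ccc(O)c1O` gives 4720 nM. Compound 2 `C=CC(C)(C)c1cc(C(=O)/C=C/c2ccc(O)c(O)c2OC)ccc1O`, which carries a 1,1-dimethylprop-2-en-1-yl group on an aromatic carbon, gives 2370 nM. These two numbers lie within the usual scatter of repeated measurements, so compound 2 stands level with compound 1 and neither can be ranked above the other.

Compound 3 `C=C(C)C(C)c1cc(C(=O)/C=C/c2ccc(O)c(O)c2OC)ccc1O` has the same atoms as compound 2, joined differently. A 1,2-dimethylprop-2-en-1-yl group takes the place of the 1,1-dimethylprop-2-en-1-yl group on an aromatic carbon, ortho to a hydroxy group (1,2-dimethylprop-2-en-1-yl in place of 1,1-dimethylprop-2-en-1-yl on an aromatic carbon). Going by the values given here, no measured pair of compounds shows what such a swap does, so the expectation rests on the structural change alone. Neither group has a ring, and each has one double bond outside aromatic rings. No step beyond the scatter is therefore expected in this assay, in either direction. Compound 2, at 2370 nM, serves as the starting point for this expectation. The estimated step of a 1.1-fold higher number from compound 2 to compound 3 (0.02 log units; within the scatter) is accordingly small. For compound 3 the expected value is 2500 nM, with an estimated range from 1100 nM to 5500 nM.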

Compound 3, half-maximal inhibitory concentration: 4950 nM
Compound 3: middle estimate off by 2.0-fold (0.30 log units), on the low side; the range from low to high includes it.
By their numbers in this assay, from the lowest: compounds 2, 1 and 3 (each within the scatter of the next, the first and the last beyond it).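

Going by these compounds alone, until now no pair of compounds differed in one place, so nothing could be said about the group on this aromatic carbon, ortho to a hydroxy group. In this assay, within the data shown here, putting 1,2-dimethylprop-2-en-1-yl in place of 1,1-dimethylprop-2-en-1-yl gives a 2.1-fold higher number from compound 2 to compound 3 (0.32 log units; beyond the scatter), a modest step, and this is the first sign that the number responds to a change at this position. The two groups have the same heavy atoms, no ring and one double bond outside aromatic rings, so only the way the same carbons are joined differs, yet that difference alone already carries the number beyond the scatter, though not by much, and nothing measured here accounts for the step.

The compounds shown cover only these two branched groups at this position, so it stays open what the straight 3-methylbut-2-en-1-yl chain, the longer geranyl chain or a cyclohexyl ring would do there. From the compounds shown here alone, it also stays open whether an amine or a carboxylic acid in this place would move the number in either direction.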